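The source may report more compounds than this note shows. Statements on the series, on what has been measured and on what is new or still open speak of the compounds shown alone.

Measured so far, in an assay on CHO cells for displacement of a labelled ligand from adenosine receptor A1 (Homo sapiens), read by scintillation counting, tested at 10 uM; on this read-out lower numbers stand for less inhibition and higher numbers for more inhibition at the one concentration tested (going by the name of the read-out): compound 1 `Cc1c(-c2ccccc2)sc(N)c1C(=O)c1ccc(Cl)cc1` gives 1%; compound 2 `COc1ccc(-c2sc(N)c(C(=O)c3ccc(Cl)cc3)c2C)cc1` gives 1%; compound 3 `CC(C)(C)Cc1c(-c2ccccc2)sc(N)c1C(=O)c1ccc(Cl)cc1` gives 1%.

The change from compound 1 to compound 2 is methoxy in place of hydrogen on an aromatic carbon and produced no change at the digits printed from compound 1 to compound 2 (within the scatter). Compound 4 `COc1ccc(-c2sc(N)c(C(=O)c3ccc(Cl)cc3)c2CC(C)(C)C)cc1`, not yet measured, carries the same change on the core of compound 3, namely (methoxy in place of hydrogen on an aromatic carbon); the place is described in the same words both times, so this is the same change. The two cores differ by tert-butyl in place of hydrogen on a saturated chain carbon bound to an aromatic carbon, which itself gave no change at the digits printed from compound 1 to compound 3 (within the scatter). The step expected from compound 3 to compound 4 in this assay is no change at the digits printed from compound 3 to compound 4 (within the scatter), resting on no change at the digits printed from compound 1 to compound 2 (within the scatter) and on the flat readings of compounds 1, 2 and 3. Compound 4 is therefore estimated at 1%, expected to fall between -6% and 10%.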

Compound 4, a percentage reported as inhibition, at one concentration (the size of the read-out at that concentration, not a potency): 1%
Compound 4: the middle estimate sits on the measured number at the digits printed, within the range that was stated.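

Methoxy in place of hydrogen gives in this assay no change at the digits printed from compound 3 to compound 4 (within the scatter), which matches its earlier step: the same change on two cores in this assay, no change at the digits printed (within the scatter) from compound 1 to compound 2 and no change at the digits printed (within the scatter) from compound 3 to compound 4, 0 percentage points apart, within the scatter of two such steps. Tert-butyl in place of hydrogen gives in this assay no change at the digits printed from compound 2 to compound 4 (within the scatter), which likewise matches its earlier step: the same change on two cores in this assay, no change at the digits printed (within the scatter) from compound 1 to compound 3 and no change at the digits printed (within the scatter) from compound 2 to compound 4, 0 percentage points apart, within the scatter of two such steps. All four compounds share one reading close to the bottom of the read-out, so the two changes are shown only to leave a flat reading flat on these cores, not to carry over unaltered on a core with measurable inhibition.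

From the compounds shown here alone, it remains open whether an amine or a hydroxyl in place of the methoxy would move the reading. The same question stands for a longer chain in place of the tert-butyl.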